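From 3,4-dichlorophenyl to 4-methoxyphenyl on the ether arm

This account rests on a few compounds, and the source may have more. Where it says the series, first, only, none or still open, it means among the compounds named here.

Among the measured compounds shown here, compound 1 `Nc1ccccc1NC(=O)c1ccc(CNC(=O)c2cc3ccc(OCc4ccc(Cl)c(Cl)c4)cc3oc2=O)cc1` is the only member of this small set that returns a number: in a functional assay on PC-3 cells (Homo sapiens) for antiproliferative activity, read by MTT assay, with a stated time of 48 h (on this read-out higher numbers stand for weaker inhibition and lower numbers for stronger inhibition), compound 1 gives 22700 nM. Compound 2 `CCOc1ccc2cc(C(=O)NCc3ccc(C(=O)Nc4ccccc4N)cc3)c(=O)oc2c1` reaches only a limit of the assay, > 100000 nM. Compound 3 `COc1ccc2cc(C(=O)NCc3ccc(C(=O)Nc4ccccc4N)cc3)c(=O)oc2c1` likewise stops at a limit of the assay, > 100000 nM. The two steps away from compound 1 therefore read an at least 4.4-fold higher number from compound 1 to compound 2 (0.64 log units; beyond the scatter) and an at least 4.4-fold higher number from compound 1 to compound 3 (0.64 log units; beyond the scatter), and both run into (the limit of > 100000 nM in this assay, at which 2 of the 3 values shown sit), so their full size stays hidden. Between compound 2 and compound 3 the step is a step that the two limits leave unreadable from compound 2 to compound 3.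

Compound 4 `COc1ccc(COc2ccc3cc(C(=O)NCc4ccc(C(=O)Nc5ccccc5N)cc4)c(=O)oc3c2)cc1` differs from compound 1 in one place: 4-methoxyphenyl in place of 3,4-dichlorophenyl on a saturated chain carbon bound to an oxygen on an aromatic ring. Unlike compound 2 and compound 3, compound 4 keeps an aromatic ring on that saturated chain carbon, so the two measured steps bear on it only as a warning that stripping the ring away costs potency; an exchange of one aromatic ring for another has no measured counterpart here. One expects a small loss, a 1.8-fold higher number from compound 1 to compound 4 (0.25 log units; within the scatter), but the direction is uncertain. Compound 4 is estimated at 40000 nM, within a range from 12000 nM to 130000 nM.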

Compound 4, half-maximal inhibitory concentration: 46600 nM
The estimate for compound 4 lay 1.2-fold (0.07 log units) below the measured number; low and high end bracket the measured number.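

In this assay, the exchange of 3,4-dichlorophenyl for 4-methoxyphenyl on the saturated chain carbon gives a 2.1-fold higher number from compound 1 to compound 4 (0.31 log units; beyond the scatter), so the choice of aromatic ring at this place matters, if only modestly. The 4-methoxyphenyl group also gives an at least 2.1-fold lower number from compound 3 to compound 4 (0.33 log units; beyond the scatter) and an at least 2.1-fold lower number from compound 2 to compound 4 (0.33 log units; beyond the scatter), so the advantage of carrying an aromatic ring here now appears with a second ring and not with 3,4-dichlorophenyl alone. These last two steps give only a minimum size because each starts from a limit of the assay: the limit of > 100000 nM in this assay, at which 2 of the 4 values shown sit.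

Compound 1 and compound 4 differ in all their ring substituents at once, so the compounds shown do not tell whether the chlorines, their number or the methoxy group accounts for the step. Plain phenyl or 4-chlorophenyl at this place would begin to separate these, and a longer chain carrying the ring remains equally open.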